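A few compounds are considered here, and "the series" means these few. Any claim that something is new, unique, unknown or untested is made for them only; others in the source may bear on it.

Measured in a functional assay on RS4-11 cells (Homo sapiens) for inhibition, read by CCK-8 assay, with a stated time of 72 h; on this read-out higher numbers stand for weaker inhibition and lower numbers for stronger inhibition:
- Compound 1 `CC1(C)CCC(CN2CCN(c3ccc(C(=O)NS(=O)(=O)c4ccc(NCC5CCOCC5)c([N+](=O)[O-])c4)c(Oc4cnc5[nH]ccc5c4)c3)CC2)=C(c2cccc(C(F)(F)F)c2)C1`: 63 nM
- Compound 2 `CC1(C)CCC(CN2CCN(c3ccc(C(=O)NS(=O)(=O)c4ccc(NCC5CCOCC5)c([N+](=O)[O-])c4)c(Oc4cnc5[nH]ccc5c4)c3)CC2)=C(c2ccc(C(F)(F)F)c(Cl)c2)C1`: 81 nM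
- Compound 3 `CN(C)CCCNc1ccc(S(=O)(=O)NC(=O)c2ccc(N3CCN(CC4=C(c5ccc(C(F)(F)F)cc5)CC(C)(C)CC4)CC3)cc2Oc2cnc3[nH]ccc3c2)cc1[N+](=O)[O-]`: 3.9 nM

Compound 3 has the lowest number of the three, beyond the scatter from both others. Compound 4 `CC1(C)CCC(CN2CCN(c3ccc(C(=O)NS(=O)(=O)c4ccc(OCC5CCOC5)c([N+](=O)[O-])c4)c(Oc4cnc5[nH]ccc5c4)c3)CC2)=C(c2ccc(C(F)(F)F)cc2)C1` differs from it in one place: (oxolan-3-yl)methoxy in place of (3-(dimethylamino)propyl)amino on an aromatic carbon. Within the data shown here, no measured step makes this change. Among the measured compounds shown here, the only step available, a 1.3-fold higher number from compound 1 to compound 2 (0.11 log units; within the scatter), alters a different part of the molecule and offers little guidance. Compound 1 at 63 nM and compound 2 at 81 nM also lack the (3-(dimethylamino)propyl)amino group, though they differ from compound 3 elsewhere too. A move to a higher number in this assay, meaning weaker inhibition, is therefore expected. The estimated change is a 13-fold higher number from compound 3 to compound 4 (1.11 log units; beyond the scatter). For compound 4 the expected value is 50 nM, with an estimated range from 12 nM to 200 nM.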

Compound 4, half-maximal inhibitory concentration: 47 nM
Beside the measured number, compound 4's estimate is 1.1-fold (0.03 log units) above it; the range from low to high includes it.
By their numbers in this assay, from the lowest: compound 3; then compounds 4, 1 and 2 (each within the scatter of the next).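

On the aromatic carbon ortho to a nitro group, putting (oxolan-3-yl)methoxy in place of (3-(dimethylamino)propyl)amino gives a 12-fold higher number from compound 3 to compound 4 (1.08 log units; beyond the scatter) in this assay. This shows that the group at this position matters in this assay, even though both groups have the same number of heavy atoms, something the earlier step, made elsewhere in the molecule, could not show. No measurement here explains the difference.

The compounds shown leave open whether the terminal dimethylamino group or the linking nitrogen counts more. A 3-(dimethylamino)propoxy group or an (oxolan-3-yl)methylamino group would separate the two.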